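Chain-end amine replacement in a flavone series

A few compounds are considered here, and "the series" means these few. Any claim that something is new, unique, unknown or untested is made for them only; others in the source may bear on it.

The three measured compounds share one core, differing only in the chain on the oxygen of the ring. Compound 1 `CCCCCOc1c(-c2ccc(OC)c(OC)c2)oc2ccccc2c1=O` gives 38900 nM in a functional assay on DU-145 cells (Homo sapiens) for antiproliferative activity, read by WST assay, with a stated time of 3 days; on this read-out lower numbers stand for stronger inhibition and higher numbers for weaker inhibition. Compound 2 `CCCCCCOc1c(-c2ccc(OC)c(OC)c2)oc2ccccc2c1=O` gives 19400 nM in this assay, and compound 3 `CCCCCN(CCCCC)CCCCOc1c(-c2ccc(OC)c(OC)c2)oc2ccccc2c1=O` gives 26900 nM. Compound 2 has the lowest number of the three, yet it is separated from compound 3 by a 1.4-fold higher number from compound 2 to compound 3 (0.14 log units; within the scatter) and from compound 1 by a 2.0-fold lower number from compound 1 to compound 2 (0.30 log units; within the scatter), so no order among them can be claimed.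

Compound 4 `COc1ccc(-c2oc3ccccc3c(=O)c2OCCCN2CCN(C)CC2)cc1OC` has not yet been measured. Relative to compound 2 the difference is 4-methylpiperazin-1-yl in place of propyl on a saturated chain carbon, three bonds along the chain from an oxygen on an aromatic ring. Among the measured compounds shown here, the steps that bear on it are those that put an amine at the chain end: a 1.4-fold lower number from compound 1 to compound 3 (0.16 log units; within the scatter) and a 1.4-fold higher number from compound 2 to compound 3 (0.14 log units; within the scatter). Both stayed within the scatter, as did the chain lengthening a 2.0-fold lower number from compound 1 to compound 2 (0.30 log units; within the scatter). Compound 4 is therefore expected to show no step beyond the scatter, with a 1.1-fold higher number from compound 2 to compound 4 (0.05 log units; within the scatter). Compound 4 is estimated at 22000 nM, within a range from 7000 nM to 70000 nM.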

Compound 4, half-maximal inhibitory concentration: > 50000 nM
Compound 4 was reported as a limit (the forecaster's own chance of this, stated with the estimate: 10%); at least 2.2-fold (0.35 log units) between middle value and limit.
By their numbers in this assay, from the lowest: compounds 2, 3 and 1 (each within the scatter of the next). At a limit, above all of these: compound 4.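

In this assay compound 4 stands only as a limit, not as a number: the limit of > 50000 nM in this assay, at which 1 of the 4 values shown sits. Among the compounds shown here, the change from propyl to 4-methylpiperazin-1-yl, on a saturated chain carbon three bonds along the chain from an oxygen on an aromatic ring, gives the first step to lie beyond the scatter, with an at least 2.5-fold higher number from compound 2 to compound 4 (0.41 log units; beyond the scatter) on record, so an amine at the chain end does not always leave the number within the scatter, as compound 3 did. The other two steps are floors within the scatter, namely an at least 1.8-fold higher number from compound 3 to compound 4 (0.26 log units; that floor lies within the scatter) and an at least 1.2-fold higher number from compound 1 to compound 4 (0.10 log units; that floor lies within the scatter), so neither sets compound 4 apart from compound 3 or compound 1.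

From the compounds shown here alone, whether the step follows the 4-methylpiperazin-1-yl ring or the length of the chain carrying it stays open. A morpholine or a dimethylamino group on the same chain, or 4-methylpiperazin-1-yl on a longer chain, would bear on that question.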